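The compounds below may be only part of what the source reports. "The series", "measured", "known", "first", "only" and "open" are said of these compounds alone.

Measured so far in a functional assay on HL-60 cells (Homo sapiens) for antiproliferative activity, read by MTT assay, with a stated time of 48 h; a higher number here means a weaker inhibitor, a lower number a stronger inhibitor:
- compound 1 `CN(C)CCn1c(N)c(-c2nc3ccccc3[nH]2)c2nc(C#N)c(C#N)nc21`: 2220 nM
- compound 2 `CN1CCN(CCn2c(N)c(-c3nc4ccccc4[nH]3)c3nc(C#N)c(C#N)nc32)CC1`: 4300 nM
- compound 3 `CCN(CC)CCCn1c(N)c(-c2nc3ccccc3[nH]2)c2nc(C#N)c(C#N)nc21`: > 730 nM (a limit of the assay, not a number)

Compound 3 has no exact place on this scale and is known only through (the limit of > 730 nM in this assay, at which 1 of the 3 values shown sits). Compound 4 `N#Cc1nc2c(-c3nc4ccccc4[nH]3)c(N)n(CCCO)c2nc1C#N` departs from compound 3 at a single point: hydroxy in place of diethylamino on a saturated chain carbon, three bonds along the chain from an aromatic nitrogen. It carries hydroxy in place of diethylamino on a saturated chain carbon, three bonds along the chain from an aromatic nitrogen, and the shared core stays as it was.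

The measured steps that bear on this change are those that exchange the group at the chain end. Only one of them has a readable size: a 1.9-fold higher number from compound 1 to compound 2 (0.29 log units; within the scatter). The other two, a step that the limit leaves unreadable from compound 1 to compound 3 and a step that the limit leaves unreadable from compound 2 to compound 3, give no size. Within the data shown here, no measured step replaces an amine with hydroxy, so the evidence is thin. The expectation therefore leans on compound 1, at 2220 nM, and compound 2, at 4300 nM, and no step beyond the scatter is expected from the exchange at the chain end. The expected step is a step that the limit leaves unreadable from compound 3 to compound 4, with no direction firmly expected. For compound 4 the estimated value is 3000 nM, with an expected range from 800 nM to 12000 nM.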

Compound 4, half-maximal inhibitory concentration: > 50000 nM
Compound 4: only a limit was reported; the forecaster's own chance of this, stated with the estimate: 25%; at least 16-fold (1.22 log units) between middle value and limit.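

In this assay, changing the group at the chain end now gives a step beyond the scatter, which the two amine-ended compounds with readable values did not show: an at least 22-fold higher number from compound 1 to compound 4 (1.35 log units; beyond the scatter) and an at least 11-fold higher number from compound 2 to compound 4 (1.06 log units; beyond the scatter). Between those two amine ends, by contrast, the printed step stays within the scatter, a 1.9-fold higher number from compound 1 to compound 2 (0.29 log units; within the scatter), so the choice of amine moved the number far less than the exchange for hydroxy in compound 4. Compound 4 is known only through a limit, as is compound 3, so every step that involves compound 3 cannot be read, including the direct exchange of diethylamino for hydroxy: the limit of > 730 nM in this assay, at which 1 of the 4 values shown sits.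

Going by these compounds, how far compound 4 lies past its limit remains open, and so does the place of compound 3 relative to the other amine-ended compounds. Also open, on these data alone, is whether a methoxy group or a primary amine at the end of the propyl chain would behave like hydroxy or like the tertiary amines, and whether a 2-hydroxyethyl group on the shorter chain would give the same large step.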